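Removing one acetyl from a trisaccharide ester

This account rests on a few compounds, and the source may have more. Where it says the series, first, only, none or still open, it means among the compounds named here.

Measured so far:
compound 1 `CCCCCCCCO[C@@H]1O[C@@H](C)[C@H](OC(=O)CCCCC)[C@@H](O[C@@H]2O[C@@H](C)[C@H](OC(C)=O)[C@@H](O[C@@H]3O[C@@H](C)[C@H](OC(C)=O)[C@@H](OC(C)=O)[C@H]3O)[C@H]2OC(C)=O)[C@H]1O` — 6 uM
compound 2 `CCCCCCCCO[C@@H]1O[C@@H](C)[C@H](OC(=O)CCCCC)[C@@H](O[C@@H]2O[C@@H](C)[C@H](OC(C)=O)[C@@H](O)[C@H]2OC(C)=O)[C@H]1O` — > 20 uM

Among the compounds with values here, in a functional assay on cells (Homo sapiens) for antiproliferative activity, read by MTT assay, with a stated time of 48 h (a lower number here means that less compound is needed, a higher number that more compound is needed for the effect), compound 1 gives 6 uM, the only true number among the two results. Compound 2 sits at the limit of > 20 uM in this assay, at which 1 of the 2 values shown sits, which is a limit of the assay and not a number. Compound 3 `CCCCCCCCO[C@@H]1O[C@@H](C)[C@H](OC(=O)CCCCC)[C@@H](O[C@@H]2O[C@@H](C)[C@H](OC(C)=O)[C@@H](O[C@@H]3O[C@@H](C)[C@H](OC(C)=O)[C@@H](O)[C@H]3O)[C@H]2OC(C)=O)[C@H]1O` has not been measured; it differs from compound 1 in one place: hydrogen in place of acetyl on an oxygen on a saturated carbon. Within the data shown here, no measured step of this kind exists, so only a modest shift is expected, if any, towards a higher value. Compound 3 is expected to give 9 uM, between 3 uM and 25 uM, an expected step of a 1.5-fold higher number from compound 1 to compound 3 (0.18 log units; within the scatter) that barely leaves the scatter.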

Compound 3, concentration for half-maximal effect: 8 uM
Beside the measured number, compound 3's estimate is 1.1-fold (0.05 log units) above it; low and high end bracket the measured number.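

In this assay, going from acetoxy to hydroxy on this oxygen on a saturated carbon gives a 1.3-fold higher number from compound 1 to compound 3 (0.12 log units; within the scatter). Within the data shown here, this is the first measured sign that this acetyl can be replaced by hydrogen without a change beyond the scatter. Nothing shown here gives a reason for this result.

Still open, as far as these compounds go, is whether a methyl ether, a longer ester such as butanoyl or an amine in this place would be tolerated in the same way. It is also unknown how the remaining acetyl groups, taken singly, contribute.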